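A few compounds are considered here, and "the series" means these few. Any claim that something is new, unique, unknown or untested is made for them only; others in the source may bear on it.

Measured compounds in a functional assay on DU-145 cells (Homo sapiens) for inhibition, read by trypan blue exclusion, with a stated time of 96 h; on this read-out higher numbers stand for weaker inhibition of growth and lower numbers for stronger inhibition of growth:
- compound 1 `O=C(/C(=C\c1cccc(Cl)c1Cl)SCc1ccc(Cl)cc1)c1ccc(Cl)cc1`: 10000 nM
- compound 2 `O=C(/C(=C\c1ccc[nH]1)SCc1ccc(Cl)cc1)c1ccc(Cl)cc1`: 10000 nM
- compound 3 `O=C(/C(=C\c1c(O)cc(O)cc1O)SCc1ccc(Cl)cc1)c1ccc(Cl)cc1`: > 100000 nM

For compound 3 the value is only a limit of the assay, not a number. Within this set compound 3 stands at the weak end: an at least 10-fold higher number from compound 1 to compound 3 (1.00 log units; beyond the scatter) and an at least 10-fold higher number from compound 2 to compound 3 (1.00 log units; beyond the scatter), both beyond the scatter, whereas no change at the digits printed from compound 1 to compound 2 (within the scatter).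

Compound 4 `Cc1ccc(C)c(/C=C(/SCc2ccc(Cl)cc2)C(=O)c2ccc(Cl)cc2)c1` is not yet measured. It differs from compound 3 thus: 2,5-dimethylphenyl in place of 2,4,6-trihydroxyphenyl on a double-bonded chain carbon bound to a double-bonded chain carbon. Among the compounds with values here, the steps that bear on this change are the two that arrive at compound 3, each at least modest and in the direction of a higher number. Removing the 2,4,6-trihydroxyphenyl again should reverse that, so a step of similar size toward a lower number is expected in this assay. The expected step is an at least 10-fold lower number from compound 3 to compound 4 (1.00 log units; beyond the scatter). Compound 4 is therefore estimated to give 10000 nM, in the range 3000 nM to 50000 nM.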

Compound 4, concentration for 50% growth inhibition: 10000 nM
Compound 4: the middle estimate sits on the measured number at the digits printed; low and high end bracket the measured number.
By their numbers in this assay, from the lowest: compounds 1, 2 and 4 (each within the scatter of the next). At a limit, above all of these: compound 3.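

In this assay, 2,5-dimethylphenyl in place of 2,4,6-trihydroxyphenyl on a double-bonded chain carbon gives an at least 10-fold lower number from compound 3 to compound 4 (1.00 log units; beyond the scatter). The new group also gives no change at the digits printed from compound 2 to compound 4 (within the scatter) and no change at the digits printed from compound 1 to compound 4 (within the scatter), so 2,5-dimethylphenyl, 2,3-dichlorophenyl and 1H-pyrrol-2-yl read alike at this place, and compound 3 alone stands apart. The value of compound 3 is a limit of the assay, not a number, so the full size of the step stays unknown: the limit of > 100000 nM in this assay, at which 1 of the 4 values shown sits.

On these data alone, whether a single hydroxyl on the phenyl ring would already move the read-out remains open. So does the reading of a phenyl carrying an amine or a carboxylic acid at this place.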